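Replacing an Allyl Ether with a Carboxymethoxyphenyl Arm

This account rests on a few compounds, and the source may have more. Where it says the series, first, only, none or still open, it means among the compounds named here.

Compound 3, `C=CCOC(c1ccc(OC)c(OC)c1OC)c1cccc2ccccc12`, sits at the weak edge of what has been measured. In a functional assay on HCT-116 cells (Homo sapiens) for inhibition, read by sulforhodamine B assay, with a stated time of 48 h (a higher number here means a weaker inhibitor, a lower number a stronger inhibitor), compound 3 gives only a limit, > 20000 nM, so its true potency is not pinned to a number. Compound 2, `COc1ccc(C(c2ccccc2O)c2cccc3ccccc23)c(OC)c1OC`, likewise gives only a limit in this assay, > 20000 nM. Among the measured compounds shown here, compound 1, `COc1ccc(C(c2ccc(OC(C)CN(C)C)cc2)c2cccc3ccccc23)c(OC)c1OC`, is the one compound with a readable value, giving 8410 nM in this assay. The step that the two limits leave unreadable from compound 2 to compound 3 cannot be sized because both of its ends rest at the limit of > 20000 nM in this assay, at which 2 of the 3 values shown sit.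

Compound 4, `COc1ccc(C(c2ccc(OCC(=O)O)cc2)c2cccc3ccccc23)c(OC)c1OC`, differs from compound 3 in a single place: 4-(carboxymethoxy)phenyl in place of allyloxy on a saturated chain carbon bound to two aromatic carbons. For the measured compounds named here, no measured step bears directly on this change. Going by the values given here, the only step that touches the same carbon is the unreadable one from compound 2 to compound 3, and no step is recorded between compound 1 and compound 4, so the most that can be said is that compound 1, carrying a different group on that carbon, gives 8410 nM in this assay. On that thin footing the change is expected to amount to an at least 1.1-fold lower number from compound 3 to compound 4 (0.04 log units; that floor lies within the scatter), a shift that cannot be called beyond the scatter. Compound 4 is therefore estimated at 18000 nM, within a range from 6000 nM to 60000 nM, with a real chance that this assay again reports only a limit.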

Compound 4, half-maximal inhibitory concentration: 5020 nM
The estimate for compound 4 lay 3.6-fold (0.55 log units) above the measured number, outside the stated range (below it).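

In this assay, placing 4-(carboxymethoxy)phenyl on the saturated chain carbon bound to two aromatic carbons gives an at least 3.9-fold lower number from compound 3 to compound 4 (0.60 log units; beyond the scatter) when it replaces allyloxy, and an at least 3.9-fold lower number from compound 2 to compound 4 (0.60 log units; beyond the scatter) when it replaces 2-hydroxyphenyl. Both steps are floors rather than full sizes, because each starts from a limit: the limit of > 20000 nM in this assay, at which 2 of the 4 values shown sit.

Compound 1 and compound 4 differ only in the group on an oxygen on an aromatic ring, and a 1.7-fold lower number from compound 1 to compound 4 (0.22 log units; within the scatter) shows that carboxymethyl and 1-((dimethylamino)methyl)ethyl cannot be told apart at that oxygen in this assay, even though one ends in a carboxylic acid and the other in an amine.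

The compounds shown leave open whether the free carboxylic acid itself matters, since its methyl ester or its amide is not among them. Also open, from the compounds shown here alone, is how a longer chain on that oxygen, or a primary amine in place of the dimethylamino end, would read in this assay.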